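Replacing a Hydroxyalkyl Tail with an Isopropyl Group

A few compounds are considered here, and "the series" means these few. Any claim that something is new, unique, unknown or untested is made for them only; others in the source may bear on it.

Compound 1 `CCCNS(=O)(=O)c1ccc(Nc2ncc3c(n2)N(C2CCCC2)[C@H](CC)C(=O)N3C)cc1` — 17.8 nM
Compound 2 `CCC1C(=O)N(C)c2cnc(-n3ccc4cc(C(=O)NC)ccc43)nc2N1c1ccn(C)n1` — 218 nM
Compound 3 `CCC1C(=O)N(C)c2cnc(Nc3ccc(S(=O)(=O)NCCCO)cc3)nc2N1c1ccn(C)n1` — 192 nM

All three were tested in an assay for inhibition of serine/threonine-protein kinase PLK2 (Homo sapiens), read by FRET and Z'-LYTE, with a stated time of 1 h; on this read-out higher numbers stand for weaker inhibition and lower numbers for stronger inhibition. On these numbers compound 3 stands second highest of the three, though its gap to compound 2 is within the usual scatter, so the two cannot be told apart; compound 1 sits far lower, a gap well beyond the scatter. Compound 4 `CCC1C(=O)N(C)c2cnc(Nc3ccc(S(=O)(=O)NCC(C)C)cc3)nc2N1c1ccn(C)n1` has not yet been measured. It differs from compound 3 by isopropyl in place of 2-hydroxyethyl on a saturated chain carbon bound to a sulfonamide nitrogen. Going by the values given here, no measured pair shows a change of this kind, so the data give no direct guide to its direction or size. The step from compound 3 to compound 4 is expected to be a 1.3-fold higher number from compound 3 to compound 4 (0.11 log units; within the scatter), a small one that may well lie within the scatter. Compound 4 is therefore expected to give about 250 nM, within a range from 100 nM to 600 nM.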

Compound 4, half-maximal inhibitory concentration: 311 nM
The estimate for compound 4 lay 1.2-fold (0.09 log units) below the measured number, within the range that was stated.
By their numbers in this assay, from the lowest: compound 1; then compounds 3, 2 and 4 (each within the scatter of the next).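

In this assay, the first change measured at this position, isopropyl in place of 2-hydroxyethyl on a saturated chain carbon bound to a sulfonamide nitrogen, gives a 1.6-fold higher number from compound 3 to compound 4 (0.21 log units; within the scatter). The tail therefore loses its hydrogen-bond donor and acceptor, as counted for these groups, with no shift that can be told from the scatter. Nothing at hand explains this result. From the compounds shown here alone, whether an amine or a carboxylic acid at the end of this chain would move the number beyond the scatter remains open, and so does the effect of a longer chain.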